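Swapping Methoxy for Chloro on a Weak Binder

This account rests on a few compounds, and the source may have more. Where it says the series, first, only, none or still open, it means among the compounds named here.

Of the compounds shown here, two that share a core have been measured in an assay on isolated protein for binding affinity to 5-hydroxytryptamine receptor 1D (Homo sapiens); a lower number here means a stronger inhibitor, a higher number a weaker inhibitor. Compound 1 `Fc1ccc(-c2n[nH]cc2N2CCCNCC2)cc1` gives 2190 nM in this assay. Compound 2 `COc1ccc(-c2n[nH]cc2N2CCNCC2)cc1` is reported in this assay only as a limit, > 10000 nM, and not as a number. That entry sits at the limit of > 10000 nM in this assay, at which 1 of the 2 values shown sits, so compound 2 stands at the weak end of what has been measured, with nothing known about how far beyond the limit it lies. Compound 3 `Clc1ccc(-c2n[nH]cc2N2CCNCC2)cc1` differs from compound 2 in one place: chloro in place of methoxy on an aromatic carbon. For the measured compounds named here, no step between measured compounds is available here, and compound 1 differs from compound 2 in more than one place, so their two values show only that one is a number and the other a limit. The step of an at least 1.2-fold lower number from compound 2 to compound 3 (0.09 log units; that floor lies within the scatter) is expected to be modest, towards a somewhat stronger binder, but with a fair chance of staying within the scatter or again ending at the limit. For compound 3 the expected value in this assay is 8000 nM, with a range from 2500 nM to 25000 nM.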

Compound 3, inhibition constant: > 10000 nM
Compound 3 ended at the assay's limit (the forecaster's own chance of this, stated with the estimate: 45%); middle value at least 1.2-fold (0.09 log units) away from the limit.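

For the compounds shown here, compound 2 and compound 3 are both reported only as limits in this assay, so no step between them can be read. The compounds shown leave open how far beyond the limit either one lies, and so whether chloro in place of methoxy on an aromatic carbon changes binding at all.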